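The source may hold more compounds than are shown below. What is called first, only, known or untested is meant among the compounds shown, and "the series" means these compounds.

Measured so far:
- compound 1, `CCOc1ccc2c(=O)c(-c3ccc(O)cc3)coc2c1`: 86.9%
- compound 2, `O=c1c(-c2ccc(O)cc2)coc2cc(CC3OC(CO)C(O)C(O)C3O)ccc12`: 0%
- compound 3, `O=c1c(-c2ccc(O)cc2)coc2cc(OCCC3OCCCO3)ccc12`: 57.6%

In a functional assay on mitochondria (Cricetulus griseus) for inhibition of Monoamine oxidase (Homo sapiens), tested at 0.9 uM (on this read-out lower numbers stand for a weaker effect and higher numbers for a stronger effect at the one concentration tested), compound 1 gives the highest of the three numbers. Its nearest neighbour is compound 3, and the difference between the two is a number 29.3 percentage points lower from compound 1 to compound 3 (beyond the scatter). Among the measured compounds shown here, compound 2 lies furthest away, and its value shows no inhibition at all in this assay, while compound 1 shows strong inhibition; for this pair no single-place step is given, so only the two values speak.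

Compound 4, `O=C(O)CCCCCCCCCOc1ccc2c(=O)c(-c3ccc(O)cc3)coc2c1`, differs from compound 1 by 7-carboxyheptyl in place of hydrogen on a saturated chain carbon, two bonds along the chain from an oxygen on an aromatic ring. For the measured compounds named here, the one measured step that bears on this change is the step from compound 1 to compound 3, where a ring-bearing group entered at the same saturated chain carbon and the value fell by a number 29.3 percentage points lower from compound 1 to compound 3 (beyond the scatter). The group entering in compound 4 is larger, a 7-carboxyheptyl chain without a ring and carrying a hydrogen-bond donor and acceptor, so a fall at least as large in this assay is expected, in the same direction.

Compound 4 is therefore expected to give about 50%, in a range from 15% to 80%, which corresponds to an estimated step of a number 36.9 percentage points lower from compound 1 to compound 4 (beyond the scatter).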

Compound 4, a percentage reported as inhibition, at one concentration (the size of the read-out at that concentration, not a potency): 85.1%
Compound 4: the middle estimate sits 35.1 percentage points below what was measured; the measured number lies above the stated range.
By their numbers in this assay, from the lowest: compound 2; then compound 3; then compounds 4 and 1 (each within the scatter of the next).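

At the saturated chain carbon two bonds along the chain from an oxygen on an aromatic ring, 7-carboxyheptyl in place of hydrogen gives a number 1.8 percentage points lower from compound 1 to compound 4 (within the scatter) in this assay, so this position accepts a long open chain with no change beyond the scatter, which the earlier ring-bearing group alone could not show. Among compound 1, compound 3 and compound 4, the size of the entering group does not follow the read-out: the group of 10 heavy atoms, set against the group of 6 heavy atoms with its six-membered non-aromatic ring, gives a number 27.5 percentage points higher from compound 3 to compound 4 (beyond the scatter) at the same carbon, and the larger group carries the higher number. Nothing measured here explains why these two groups part ways in this way.

On these data alone, the comparison of compound 3 with compound 4 changes the ring and the chain end together, so it remains open which of the two goes with the difference. An amine or a plain methyl end in place of the carboxylic acid on the same chain, or a shorter or longer chain with the same acid end, would be needed to separate these features.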